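Urotensin-2 agonist series: methoxy to trifluoromethyl swap

The source may report more compounds than this note shows. Statements on the series, on what has been measured and on what is new or still open speak of the compounds shown alone.

Working notes on a small set of amides built on the core of compound 2 `COc1ccc(CCC(=O)NC(CCN(C)C)c2ccc3ccccc3c2)cc1`. Three members have been measured in a functional assay on NIH3T3 cells for agonist activity at Urotensin-2 receptor (Homo sapiens), with a stated time of 5 days; a higher number here means a larger maximal response, a lower number a smaller maximal response. Compound 1 `COc1ccc(/C=C/C(=O)NC(CCN(C)C)c2ccc3ccccc3c2)cc1` gives 106%, compound 2 gives 113%, and compound 3 `COc1ccc(/C=C/C(=O)NC(CCN(C)C)c2ccc(Cl)cc2)cc1` gives 99%. Compound 2 stands highest of the three numbers; its gap to compound 1 lies within the scatter, its gap to compound 3 lies beyond it. For the measured compounds named here, no two measured compounds differ in one place only, so no single measured step is available to lean on.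

Compound 4 `CN(C)CCC(NC(=O)CCc1ccc(C(F)(F)F)cc1)c1ccc2ccccc2c1` is not yet measured. Relative to compound 2 it carries trifluoromethyl in place of methoxy on an aromatic carbon, the 4-methoxyphenyl becoming a 4-(trifluoromethyl)phenyl. All three measured maximal responses sit near the reference, and nothing in the set ties the methoxy to the size of the response. The step is therefore expected to be small, a number 10 percentage points lower from compound 2 to compound 4 (within the scatter), in no direction beyond the scatter. Compound 4 is estimated at 103% in this assay this assay, with a range from 80% to 120%.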

Compound 4, largest response reached (reported as efficacy), in percent of the reference or control that the assay uses: 75%
Compound 4: middle estimate off by 28 percentage points, on the high side, outside the stated range (below it).
By their numbers in this assay, from the lowest: compound 4; then compounds 3, 1 and 2 (each within the scatter of the next, the first and the last beyond it).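

In this assay, for the compounds shown here, the change to trifluoromethyl in place of methoxy on an aromatic carbon, para to a large group, gives a number 38 percentage points lower from compound 2 to compound 4 (beyond the scatter) and is the first step that differs in one place only. Going by these compounds alone, it shows that the maximal response depends on the group at this position, which the earlier compounds could not show, since all three carry the 4-methoxyphenyl. Nothing at hand gives a measured basis for explaining the drop.

On these data alone, whether the drop comes from losing the methoxy or from gaining the trifluoromethyl remains open, and so does whether the same change would act alike on compound 1. A hydrogen, a hydroxyl or a chlorine at this position would help separate these two readings.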